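The compounds below may be only part of what the source reports. "The series", "measured", "known", "first", "only" and "open" are said of these compounds alone.

Three compounds of the series have been run in a physicochemical assay for lipophilicity, using the shake flask method, in phosphate buffer, measured as octanol-water partition, with a stated time of 30 min, at pH 7.4; on this read-out higher numbers stand for higher lipophilicity and lower numbers for lower lipophilicity. Compound 1 `CNC(=O)c1cc(-c2cnc(NCc3c(F)ccc4c3CCO4)c3cn[nH]c(=O)c23)n(C)n1` gives 2.1 in this assay. Compound 3 `CN(C)Cc1ccc2c(c1)CN(c1cnc(NCc3c(F)ccc4c3CCO4)c3cn[nH]c(=O)c13)C2=O` gives 2.2. Compound 2 `O=C1CCCN1c1cnc(NCc2c(F)ccc3c2CCO3)n2cnnc12` gives 1.3, the lowest of the three numbers; its gap to compound 1 and its gap to compound 3 both lie beyond the usual scatter. Compound 4 `O=C1CC2(CC2)CN1c1cnc(NCc2c(F)ccc3c2CCO3)n2cnnc12` has not yet been measured. Relative to compound 2 it carries a group of 8 heavy atoms (6 carbon, 1 nitrogen, 1 oxygen; one three-membered non-aromatic ring of carbon only, one five-membered non-aromatic ring with 1 hetero atom) in place of a group of 6 heavy atoms (4 carbon, 1 nitrogen, 1 oxygen; one five-membered non-aromatic ring with 1 hetero atom), on an aromatic carbon. Going by the values given here, no measured pair in the set shows this change, so the size of the step is not known from data; an upward step, modest but probably beyond the scatter, is expected. The estimated step is a number 0.50 log units higher from compound 2 to compound 4 (beyond the scatter). Compound 4 is therefore expected near 1.8, within 1.4 to 2.3.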

Compound 4, distribution coefficient: 1.9
The estimate for compound 4 lay 0.10 log units below the measured number; the range from low to high includes it.
By their numbers in this assay, from the lowest: compound 2; then compounds 4, 1 and 3 (each within the scatter of the next).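

At this position, on an aromatic carbon of a six-membered aromatic ring, the read-out responds to a change in the ring group alone: in this assay, adding the three-membered carbon ring gives a number 0.60 log units higher from compound 2 to compound 4 (beyond the scatter). The entering group differs from 2-oxopyrrolidin-1-yl by carbon atoms only, with hydrogen-bond donors, hydrogen-bond acceptors and net charge unchanged. Nothing available accounts for the size of this step.

Open, going by these compounds, is whether an amine or a carboxylic acid on the five-membered ring would shift the number downward. Also open, on these data alone, is whether the same change on the core of compound 1 gives a similar step.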